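Swapping the Chlorophenyl Group on a Weak Deacetylase Inhibitor

A few compounds are considered here, and "the series" means these few. Any claim that something is new, unique, unknown or untested is made for them only; others in the source may bear on it.

Compound 1, `O=C1NC(=O)/C(=C\c2ccc(OCC(=O)N3N=C(c4ccccc4)CC3c3ccccc3Cl)cc2)S1`: 29000 nM
Compound 2, `O=C1NC(=O)/C(=C\c2ccc(OCC(=O)N3N=C(c4ccccc4)CC3c3ccc(F)cc3)cc2)S1`: 26000 nM
Compound 3, `O=C1NC(=O)/C(=C\c2ccc(OCC(=O)N3N=C(c4ccc(F)cc4)CC3c3ccccc3Cl)cc2)S1`: > 50000 nM

Of the compounds shown here, three built on one shared core have been tested in an assay on cells for inhibition of histone deacetylase 8 (Homo sapiens), read by fluorescence, with a stated time of 30 min; on this read-out lower numbers stand for stronger inhibition and higher numbers for weaker inhibition. Compound 1 gives 29000 nM and compound 2 gives 26000 nM. The step of a 1.1-fold lower number from compound 1 to compound 2 (0.05 log units; within the scatter) exchanges the group on a saturated ring carbon and stays within the scatter. For compound 3 the assay reports no number, only a limit, > 50000 nM. Among the values shown, compound 3 stands at the limit of > 50000 nM in this assay, at which 1 of the 3 values shown sits. The step of an at least 1.7-fold higher number from compound 1 to compound 3 (0.23 log units; that floor lies within the scatter) therefore has only a floor, and that floor lies within the scatter.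

Compound 4, `O=C1NC(=O)/C(=C\c2ccc(OCC(=O)N3N=C(c4ccc(F)cc4)CC3c3ccc(Cl)c(Cl)c3)cc2)S1`, differs from compound 3 by 3,4-dichlorophenyl in place of 2-chlorophenyl on a saturated ring carbon. Going by the values given here, the only measured step that bears on this change is a 1.1-fold lower number from compound 1 to compound 2 (0.05 log units; within the scatter), which also replaced the group on that saturated ring carbon and produced no shift beyond the scatter. The expected step that the limit leaves unreadable from compound 3 to compound 4 is accordingly no change beyond the scatter. Compound 4 is estimated at 65000 nM in this assay, between 25000 nM and 170000 nM, and a limit rather than a number is the most likely report.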

Compound 4, half-maximal inhibitory concentration: 25000 nM
For compound 4 the middle estimate is 2.6-fold (0.41 log units) above the measured one; the measured number falls inside the stated range.
By their numbers in this assay, from the lowest: compounds 4, 2 and 1 (each within the scatter of the next). At a limit, above all of these: compound 3.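

Compound 4 gives a readable number where compound 3 gave only a limit, so with the 4-fluorophenyl group kept, 3,4-dichlorophenyl on the saturated ring carbon still yields a value in this assay. The change amounts to an at least 2.0-fold lower number from compound 3 to compound 4 (0.30 log units; that floor lies within the scatter), so it cannot be called a gain beyond the scatter. From the compounds shown here alone, the true size of this step stays unknown because compound 3 sits at a limit: the limit of > 50000 nM in this assay, at which 1 of the 4 values shown sits.

The compounds shown leave open whether either chlorine of 3,4-dichlorophenyl matters on its own, and whether this swap would read the same with the plain phenyl group of compound 1 in place of 4-fluorophenyl. They also leave open what an amine or a carboxylic acid on that aromatic ring would give.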